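The source may hold more compounds than are shown below. What is called first, only, known or untested is meant among the compounds shown, and "the series" means these compounds.

In an assay on CHO cells for displacement of a labelled ligand from adenosine receptor A1 (Homo sapiens) (on this read-out higher numbers stand for weaker inhibition and lower numbers for stronger inhibition), compound 3 `CCCn1c(=O)c2nc(-c3cnn(Cc4ccccc4C(F)(F)F)c3)[nH]c2n(CCC)c1=O` gives 44 nM, the lowest of the two numbers reported so far: compound 1 `CCCn1c(=O)c2nc(-c3cnn(Cc4cc(Cl)ccc4Cl)c3)[nH]c2n(CCC)c1=O` gives 190 nM, and the change in this assay was a 4.3-fold lower number from compound 1 to compound 3 (0.64 log units; beyond the scatter). Compound 2 `CCCn1c(=O)c2nc(-c3cnn(Cc4c(F)cccc4F)c3)[nH]c2n(CCC)c1=O` has "not determined" (no result reported) in this assay. Compound 4 `CCCn1c(=O)c2nc(-c3cnn(Cc4ccccc4C)c3)[nH]c2n(CCC)c1=O` differs from compound 3 by methyl in place of trifluoromethyl on an aromatic carbon. For the measured compounds named here, no measured step covers this exchange; the only step available, from compound 1 to compound 3, put 2-(trifluoromethyl)phenyl in place of 2,5-dichlorophenyl, so it is a loose guide at best. With nothing in the data pointing firmly either way, compound 4 is expected to land near compound 3 or a little higher, a 1.7-fold higher number from compound 3 to compound 4 (0.23 log units; within the scatter). Compound 4 is therefore estimated at 75 nM in this assay, with a range from 25 nM to 220 nM.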

Compound 4, inhibition constant: 22 nM
Beside the measured number, compound 4's estimate is 3.4-fold (0.53 log units) above it, outside the stated range (below it).
By their numbers in this assay, from the lowest: compounds 4 and 3 (each within the scatter of the next); then compound 1.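

In this assay, methyl in place of trifluoromethyl on this aromatic carbon, ortho to a large group, gives a 2.0-fold lower number from compound 3 to compound 4 (0.30 log units; within the scatter), so the two groups cannot be told apart here despite their different heavy-atom counts. The change from 2,5-dichlorophenyl to 2-methylphenyl gives an 8.6-fold lower number from compound 1 to compound 4 (0.94 log units; beyond the scatter), a step beyond the scatter, so 2-methylphenyl joins 2-(trifluoromethyl)phenyl on the low side of compound 1. Nothing available explains these results. The compounds shown leave open whether plain hydrogen, a methoxy group or an amine on this carbon would give similar numbers.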